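Replacing a Chloro with a Methyl on an Antagonist

The source may report more compounds than this note shows. Statements on the series, on what has been measured and on what is new or still open speak of the compounds shown alone.

Compound 1 `O=C(O)Cc1sc(Cc2ccc(Cl)cc2)nc1-c1ccccc1` is the starting point. Among the measured compounds shown here, in an in vitro functional assay on HEK285-7 cells for antagonist activity at prostaglandin D2 receptor 2 (Homo sapiens), read by BRET and beta-arrestin recruitment (on this read-out lower numbers stand for stronger inhibition and higher numbers for weaker inhibition), compound 1 gives 580 nM, which is the second highest of the three numbers measured so far. Compound 2 `O=C(O)Cc1sc(Cc2ccc(Cl)cc2)nc1-c1ccc(Cl)cc1` gives 220 nM, and the change from compound 1 to compound 2, a chloro in place of a hydrogen on an aromatic carbon, brings a 2.6-fold lower number from compound 1 to compound 2 (0.42 log units; beyond the scatter). Compound 3 `COc1ccc(-c2nc(Cc3ccc(Cl)cc3)sc2CC(=O)O)cc1` gives 850 nM, and the step with a methoxy in place of hydrogen reads a 1.5-fold higher number from compound 1 to compound 3 (0.17 log units; within the scatter). The step from compound 2 to compound 3, methoxy in place of chloro, is a 3.9-fold higher number from compound 2 to compound 3 (0.59 log units; beyond the scatter).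

Compound 4 `Cc1ccc(Cc2nc(-c3ccccc3)c(CC(=O)O)s2)cc1` is not yet measured. It differs from compound 1 in one place: methyl in place of chloro on an aromatic carbon. For the measured compounds named here, none of the measured steps involves a methyl, so the closest guides are the gain seen with chloro in compound 2 and the loss seen with methoxy in compound 3, both against compound 1. Since compound 4 gives up the chloro without taking on a methoxy, the expected outcome is a number close to that of compound 1, with a step from compound 1 to compound 4 estimated at a 1.2-fold higher number from compound 1 to compound 4 (0.08 log units; within the scatter). Compound 4 is therefore expected to give about 700 nM, within a range from 350 nM to 1400 nM.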

Compound 4, half-maximal inhibitory concentration: 1800 nM
Compound 4: middle estimate off by 2.6-fold (0.41 log units), on the low side, outside the stated range (above it).
By their numbers in this assay, from the lowest: compound 2; then compounds 1 and 3 (each within the scatter of the next); then compound 4.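

In this assay, exchanging the chloro of the 4-chlorophenyl group for a methyl gives a 3.1-fold higher number from compound 1 to compound 4 (0.49 log units; beyond the scatter), so inhibition weakens by more than the usual scatter and this position is shown to respond to the change. Among the compounds shown here, compounds 2 and 3 both keep the 4-chlorophenyl group and differ from compound 1 on the other aromatic ring, which makes compound 4 the only view of this position so far; the step also separates two groups that match in everything counted here, each having one heavy atom, no hydrogen-bond donors or acceptors, and no net charge. No measurement offered here explains why the methyl gives the weaker result.

The compounds shown leave open how a plain hydrogen, a fluoro, a methoxy or an amine would read at this same position, and so whether chloro stands out or methyl is the exception. From the compounds shown here alone, it also remains open whether the gain from the second chloro in compound 2 would carry over to a molecule that has the methyl in place of the first chloro.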